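Replacing a Cycloheptyl Amide Group with a Hydroxyamide

The source may report more compounds than this note shows. Statements on the series, on what has been measured and on what is new or still open speak of the compounds shown alone.

Measured so far in an assay on cell membranes for binding affinity to 2-oxoglutarate receptor 1 (Rattus norvegicus), read by radioligand binding; on this read-out lower numbers stand for stronger inhibition and higher numbers for weaker inhibition:
compound 1, `NC(=O)[C@H]1OC(n2cnc3c(N)ncnc32)[C@H](O)[C@@H]1O`, gives 64 nM in this assay
compound 2, `CCCCCCCNC(=O)[C@H]1OC(n2cnc3c(N)ncnc32)[C@H](O)[C@@H]1O`, gives 20 nM in this assay
compound 3, `Nc1ncnc2c1ncn2C1O[C@H](C(=O)NC2CCCCCC2)[C@@H](O)[C@H]1O`, gives 22 nM in this assay

Compound 3 holds the second highest of these three numbers. Its nearest neighbour is compound 2, separated only by a 1.1-fold higher number from compound 2 to compound 3 (0.04 log units; within the scatter), which lies within the scatter; its furthest is compound 1, separated by a 2.9-fold lower number from compound 1 to compound 3 (0.46 log units; beyond the scatter), which lies beyond it.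

Compound 4, `Nc1ncnc2c1ncn2C1O[C@H](C(=O)NO)[C@@H](O)[C@H]1O`, differs from compound 3 in one place: hydroxy in place of cycloheptyl on an amide-type nitrogen. Going by the values given here, two measured steps bear on this. a 2.9-fold lower number from compound 1 to compound 3 (0.46 log units; beyond the scatter) and a 3.2-fold lower number from compound 1 to compound 2 (0.51 log units; beyond the scatter) both show that placing a seven-carbon group on the amide nitrogen lowered the number modestly, and a 1.1-fold higher number from compound 2 to compound 3 (0.04 log units; within the scatter) shows that ring and chain gave the same result within the scatter. Compound 4 gives up that seven-carbon group entirely and puts a single hydroxy in its place. Among the compounds with values here, no measured compound carries hydroxy on this nitrogen, so the closest guide is compound 1, which carries hydrogen there. The expectation is therefore a modest move back upward, roughly undoing the gain seen in a 2.9-fold lower number from compound 1 to compound 3 (0.46 log units; beyond the scatter), so that a 2.7-fold higher number from compound 3 to compound 4 (0.44 log units; beyond the scatter) is expected.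

Compound 4 is estimated at 60 nM, with a range from 25 nM to 150 nM.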

Compound 4, inhibition constant: 41 nM
Estimate against measurement, compound 4: 1.5-fold (0.17 log units) above; the range from low to high includes it.
By their numbers in this assay, from the lowest: compounds 2, 3, 4 and 1 (each within the scatter of the next, the first and the last beyond it).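

In this assay the amide-type nitrogen now proves able to carry something other than hydrogen or a seven-carbon group: hydroxy cannot be told apart from cycloheptyl (a 1.9-fold higher number from compound 3 to compound 4 (0.27 log units; within the scatter)) or from hydrogen (a 1.6-fold lower number from compound 1 to compound 4 (0.19 log units; within the scatter)). Only against heptyl does the same change pass the scatter (a 2.1-fold higher number from compound 2 to compound 4 (0.31 log units; beyond the scatter)), a modest step, and it should be read with care, as compound 2 and compound 3 are themselves within the scatter of each other. So cycloheptyl can be removed from this nitrogen without a step beyond the scatter, and no supporting data are available to explain why.

Open, on these data alone, is whether other groups on this nitrogen, such as methoxy, an amine or a chain shorter than heptyl, would also stay within the scatter of compound 4 or would separate clearly from compound 1. Also open, as far as these compounds go, is how hydroxy on this nitrogen would read at any receptor other than this one, which matters for judging whether the change has any use beyond this single binding number.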